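The source may hold more compounds than are shown below. What is called first, only, known or untested is meant among the compounds shown, and "the series" means these compounds.

Measured compounds in a functional assay on FM3A cells (Mus musculus), with a stated time of 2 days; on this read-out higher numbers stand for weaker inhibition and lower numbers for stronger inhibition:
compound 1 `C=C1C=CCO[C@@H]1n1cc(C)c(O)nc1=O`: >= 900000 nM, a limit of the assay rather than a number.
compound 2 `O=C1C=CCO[C@@H]1n1ccc(O)nc1=O`: 121000 nM.
compound 3 `C=C1[C@H](O)[C@H](O)CO[C@@H]1n1cc(C)c(O)nc1=O`: 775000 nM.

Compound 1 stands at the edge of what this assay reports: the limit of >= 900000 nM in this assay, at which 1 of the 3 values shown sits. Compound 3 gives a number inside the reported range, as does compound 2. Among the measured compounds shown here, no two of these three compounds differ in a single place, so no measured step can be drawn between them, and the numbers for compounds 2 and 3 are taken only as they stand.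

Compound 4 `C=C1C=CCO[C@@H]1n1ccc(O)nc1=O` is the analogue of compound 1 with hydrogen in place of methyl on an aromatic carbon. For the measured compounds named here, no measured pair here isolates this change. Compound 2, which also carries hydrogen at that aromatic carbon on a different core, gives 121000 nM, and on that basis a move toward lower numbers is expected for compound 4, beyond the usual scatter but uncertain in size. A step of an at least 2.2-fold lower number from compound 1 to compound 4 (0.35 log units; beyond the scatter) is expected in this assay. For compound 4 the estimate is 400000 nM, with a range from 120000 nM to 1000000 nM.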

Compound 4, half-maximal inhibitory concentration: > 1000000 nM
Compound 4: a limit, no number; the forecaster's own chance of this, stated with the estimate: 35%; middle value at least 2.5-fold (0.39 log units) away from the limit.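

No step can be read from compound 1 to compound 4 in this assay, because compound 4 stands at a limit and not at a number: the limit of > 1000000 nM in this assay, at which 1 of the 4 values shown sits. Compound 1 also stands at a limit: the limit of >= 900000 nM in this assay, at which 1 of the 4 values shown sits. The compounds shown leave open whether hydrogen in place of methyl on an aromatic carbon changes the read-out on this core at all.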